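This account rests on a few compounds, and the source may have more. Where it says the series, first, only, none or still open, it means among the compounds named here.

Compound 1 `CN1CCC(n2cc(S(=O)(=O)c3cccc(Cl)c3)c3cccnc32)C1` is the starting point of this short series. In an assay on HeLa cells for displacement of a labelled ligand from 5-hydroxytryptamine receptor 6 (Homo sapiens) (on this read-out higher numbers stand for weaker inhibition and lower numbers for stronger inhibition), compound 1 gives 1.5 nM. Compound 2 `CN1CCC(n2cc(S(=O)(=O)c3ccc(Cl)cc3)c3cccnc32)C1` differs from it only in the aryl group on the sulfonyl sulfur, (4-chlorophenyl in place of 3-chlorophenyl on a sulfonyl sulfur), and in this assay compound 2 gives 4.2 nM, so that the change produced a 2.8-fold higher number from compound 1 to compound 2 (0.45 log units; beyond the scatter).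

Compound 3 `O=S(=O)(c1cccc(Cl)c1)c1cn(C2CCCNC2)c2ncccc12` keeps the 3-chlorophenyl of compound 1 but carries a different saturated ring on the aromatic nitrogen of the shared core, (piperidin-3-yl in place of 1-methylpyrrolidin-3-yl on an aromatic nitrogen). In this assay compound 3 gives 1.3 nM, and the step of a 1.2-fold lower number from compound 1 to compound 3 (0.06 log units; within the scatter) shows that this exchange of the saturated ring left the read-out essentially where it was.

Compound 4 `O=S(=O)(c1ccc(Cl)cc1)c1cn(C2CCCNC2)c2ncccc12` has not yet been measured. It relates to compound 3 exactly as compound 2 relates to compound 1: the difference is 4-chlorophenyl in place of 3-chlorophenyl on a sulfonyl sulfur, and the place is described in the same words for both pairs, so the change is the same one made once already. Among the measured compounds shown here, the only precedent for it is the step of a 2.8-fold higher number from compound 1 to compound 2 (0.45 log units; beyond the scatter), which, on the scaffold of compound 1, pushed the number beyond the scatter. With the saturated ring having shown so little effect in a 1.2-fold lower number from compound 1 to compound 3 (0.06 log units; within the scatter), a step of similar size is expected when the aryl group is moved on the piperidin-3-yl scaffold. Compound 4 is therefore expected to show a 2.8-fold higher number from compound 3 to compound 4 (0.44 log units; beyond the scatter). Compound 4 is estimated at 3.6 nM, with a likely range from 1.8 nM to 7.2 nM.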

Compound 4, inhibition constant: 7.6 nM
Beside the measured number, compound 4's estimate is 2.1-fold (0.32 log units) below it; measured number outside the range, above it.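

In this assay, the exchange of 3-chlorophenyl for 4-chlorophenyl on the sulfonyl sulfur gave a 5.8-fold higher number from compound 3 to compound 4 (0.77 log units; beyond the scatter), so the change raised the number on both cores, and the two steps do not differ in size by more than the scatter allows: the same change on two cores in this assay, a 2.8-fold higher number (0.45 log units; beyond the scatter) from compound 1 to compound 2 and a 5.8-fold higher number (0.77 log units; beyond the scatter) from compound 3 to compound 4, 2.1-fold (0.32 log units) apart, within the scatter of two such steps. The exchange of 1-methylpyrrolidin-3-yl for piperidin-3-yl on the aromatic nitrogen gave a 1.8-fold higher number from compound 2 to compound 4 (0.26 log units; within the scatter), which, like the earlier step for this change, stays within the scatter, so this change also carried over: the same change on two cores in this assay, a 1.2-fold lower number (0.06 log units; within the scatter) from compound 1 to compound 3 and a 1.8-fold higher number (0.26 log units; within the scatter) from compound 2 to compound 4, 2.1-fold (0.32 log units) apart, within the scatter of two such steps. Among the compounds shown here, these four compounds supply only two steps for each change, so they do not show that the aryl change costs more on one core than on the other, and they cannot say whether either change would carry over to any further core.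

The compounds shown leave open whether a different group on the phenyl ring, such as fluorine, methoxy or trifluoromethyl, would give a similar step between the 3-substituted and 4-substituted forms. They also leave open how the number would respond to other saturated rings on the aromatic nitrogen, such as 1-methylpiperidin-3-yl or the unmethylated pyrrolidin-3-yl.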